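Swapping acetamido for trifluoromethyl on a shared core

This account rests on a few compounds, and the source may have more. Where it says the series, first, only, none or still open, it means among the compounds named here.

Of the compounds shown here, three built on the same fused core have been measured in an assay on HEK293 cells for binding affinity to Neuronal acetylcholine receptor; alpha4/beta2 (Homo sapiens); a higher number here means a weaker inhibitor, a lower number a stronger inhibitor. Compound 1 `CC(C)c1nc2cc3c(cc2o1)C1CNCC3C1` gives 1.9 nM, and compound 2 `Fc1cc2c(cc1F)C1CNCC2C1` gives 0.28 nM. Compound 3 `CC(=O)Nc1ccc2c(c1)C1CNCC2C1`, which carries an acetamido group on its aromatic ring, gives 75 nM, the highest number of the three and therefore the weakest binder among them; its gap to compound 1 and its larger gap to compound 2 both lie well beyond the usual scatter.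

The next compound keeps the core and changes only the aromatic substituent. Compound 4 `FC(F)(F)c1ccc2c(c1)C1CNCC2C1` differs from compound 3 as follows: trifluoromethyl in place of acetamido on an aromatic carbon.

Going by the values given here, no pair of measured compounds differs in just this one place, so the size of the step cannot be read off directly. The two lower numbers belong to compound 1 and compound 2, neither of which bears a hydrogen-bond donor or acceptor on that ring, while compound 3 does and stands highest. On that basis a clear move toward a lower number is expected in this assay, beyond the scatter, though not necessarily all the way down to compound 2. Compound 4 is therefore estimated at 8 nM, plausibly between 2 nM and 40 nM, an expected step of a 9.4-fold lower number from compound 3 to compound 4 (0.97 log units; beyond the scatter).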

Compound 4, inhibition constant: 0.33 nM
Compound 4: middle estimate off by 24-fold (1.38 log units), on the high side, and the stated range ends above it.
By their numbers in this assay, from the lowest: compounds 2 and 4 (each within the scatter of the next); then compound 1; then compound 3.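

In this assay, going by these compounds alone, the first step that can be read at a single place on the shared core comes from trifluoromethyl in place of acetamido on this aromatic carbon, and at a 230-fold lower number from compound 3 to compound 4 (2.36 log units; beyond the scatter) it is a large one. The change therefore matters greatly at this position, even though the two groups match in heavy-atom count and neither contains a ring: they differ in their atoms, with acetamido counting a hydrogen-bond donor, a hydrogen-bond acceptor and a double bond, and trifluoromethyl none of these. Nothing available here shows why the step is so large.

This one step cannot tell whether the change in the number follows the loss of the amide hydrogen, the loss of the carbonyl, or the arrival of the fluorines. On these data alone, a free amine, a methoxy group or a nitrile on the same aromatic carbon could begin to separate these possibilities, and it also remains open whether the same swap would give a step of similar size on another aromatic carbon of this ring.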